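Swapping Chloro for Nitro on an Aromatic Carbon

The source may report more compounds than this note shows. Statements on the series, on what has been measured and on what is new or still open speak of the compounds shown alone.

In a functional assay on the whole organism (stomach) with Rattus norvegicus as the target (a lower number here means that less compound is needed, a higher number that more compound is needed for the effect), compound 1 (`COc1ccc(C(=O)Nc2cc(C(=O)O)cc(C(=O)O)c2)cc1OC`) gives 116 mg/kg and compound 2 (`O=C(O)c1cc(NC(=O)c2cc(O)cc(O)c2)cc(C(=O)O)c1`) gives 90.2 mg/kg while compound 3 (`O=C(O)c1cc(NC(=O)c2ccc(Cl)cc2)cc(C(=O)O)c1`) gives 97.3 mg/kg on the same scale. These three numbers all lie within the usual scatter of one another, so compound 3 stands level with both of the others.

The next compound to be tested is compound 4 (`O=C(O)c1cc(NC(=O)c2ccc([N+](=O)[O-])cc2)cc(C(=O)O)c1`), which carries nitro in place of chloro on an aromatic carbon, para to a large group (nitro in place of chloro on an aromatic carbon). For the measured compounds named here, no two measured compounds differ in only one place, so the data hold no direct measure of what such a swap does. Compound 1 at 116 mg/kg and compound 3 at 97.3 mg/kg do carry different groups on the shared core, yet their numbers stay within the scatter, and that is the basis for expecting no step beyond it here. The expected change is a 1.0-fold higher number from compound 3 to compound 4 (0.01 log units; within the scatter) and it stays within the scatter. For compound 4 the estimated value is 100 mg/kg with an estimated range from 55 mg/kg to 180 mg/kg around it.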

Compound 4, dose for 50% inhibition: 61.1 mg/kg
Compound 4: the middle estimate sits 1.6-fold (0.21 log units) above what was measured; the measured number falls inside the stated range.
By their numbers in this assay, from the lowest: compounds 4, 2, 3 and 1 (each within the scatter of the next).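

For the compounds shown here, this is the first pair that differs in one place only: nitro in place of chloro on an aromatic carbon, para to a large group, gives a 1.6-fold lower number from compound 3 to compound 4 (0.20 log units; within the scatter) in this assay. The swap adds heavy atoms and hydrogen-bond acceptors, yet the step stays within the usual scatter, so this single change shows no clear effect at this position. No supporting measurement bears on the result, so the data offer no explanation for it.

Going by these compounds, how an amine or a longer alkyl chain on this same aromatic carbon would compare with chloro and nitro stays open. Also open, on these data alone, is whether a larger step is possible here at all, since this single pair cannot show how far the number can move at this position.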